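The compounds below may be only part of what the source reports. "The series", "measured", "known", "first", "only" and "open" are said of these compounds alone.

Compound 1, `CCC(C)COc1cccc2ccc(N)nc12`, gives 36 nM in an assay on cells with melanin-concentrating hormone receptor 1 (Homo sapiens) as the target, read by radioligand binding (on this read-out higher numbers stand for weaker inhibition and lower numbers for stronger inhibition), the lowest of the three numbers measured. Compound 2, `CCCOc1cccc2ccc(N)nc12`, gives 1100 nM, and compound 3, `Nc1ccc2cccc(OCC3CCC3)c2n1`, gives 432 nM. The steps show a 31-fold higher number from compound 1 to compound 2 (1.49 log units; beyond the scatter), a 12-fold higher number from compound 1 to compound 3 (1.08 log units; beyond the scatter) and a 2.5-fold lower number from compound 2 to compound 3 (0.41 log units; beyond the scatter), so every change away from sec-butyl on a saturated chain carbon bound to an oxygen on an aromatic ring seen so far has raised the number.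

Compound 4, `CC(C)OCCOc1cccc2ccc(N)nc12`, differs from compound 1 by isopropoxymethyl in place of sec-butyl on a saturated chain carbon bound to an oxygen on an aromatic ring. The closest comparison is the step from compound 1 to compound 3, where cyclobutyl replaced sec-butyl at the same place and the number rose, and the step from compound 1 to compound 2 points the same way. Among the measured compounds shown here, no measured compound carries an oxygen in this chain, so the estimate rests on the direction of those two steps. Compound 4 is therefore expected to give a higher number than compound 1, estimated as a 9.7-fold higher number from compound 1 to compound 4 (0.99 log units; beyond the scatter), with a value of 350 nM and a range from 80 nM to 1500 nM.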

Compound 4, half-maximal inhibitory concentration: > 2000 nM
Compound 4 gave a limit, no number; the forecaster's own chance of this, stated with the estimate: 3%; at least 5.7-fold (0.75 log units) between middle value and limit.
By their numbers in this assay, from the lowest: compound 1; then compound 3; then compound 2. At a limit, above all of these: compound 4.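

For compound 4, the > 2000 nM in this assay is a limit and not a number: the limit of > 2000 nM in this assay, at which 1 of the 4 values shown sits. Even so, the change to 2-isopropoxyethyl from 2-methylbutyl gives an at least 55-fold higher number from compound 1 to compound 4 (1.74 log units; beyond the scatter), and the change from the cyclobutyl group gives an at least 4.6-fold higher number from compound 3 to compound 4 (0.66 log units; beyond the scatter), so a branched group at this place does not by itself keep the number low, and a chain carrying an oxygen can stand well apart from the all-carbon sec-butyl chain of compound 1. The comparison with the shorter chain reads an at least 1.8-fold higher number from compound 2 to compound 4 (0.25 log units; that floor lies within the scatter), so this limit sets no firm order between those two compounds.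

On these data alone, it remains open how far above the limit compound 4 lies, and whether the chain oxygen or the place of the branch accounts for the rise. As far as these compounds go, how an amine at the same place in the chain, or a longer all-carbon chain, would read also remains open.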